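The source may hold more compounds than are shown below. What is called first, only, known or untested is meant among the compounds shown, and "the series" means these compounds.

Measured compounds:
compound 1, `Cc1c(C)c2c(c(C)c1O)CC[C@@](C)(CC[N+](C)(C)C)O2` — in a functional assay (brain) for inhibition, with Rattus norvegicus as the target (a higher number here means a weaker inhibitor, a lower number a stronger inhibitor), compound 1 gives 2300 nM
compound 2, `Cc1c(C)c2c(c(C)c1O)CC[C@](C)(CC[S+](C)C)O2` — in this assay compound 2 gives 2000 nM

Compound 1 has the higher of the two numbers, but the value of compound 2 lies within the usual scatter of such measurements, so the two cannot be placed in order.

Compound 3, `Cc1c(C)c2c(c(C)c1O)CC[C@@](C)(CCN(C)C)O2`, is not yet measured. Compared with compound 1 it differs as follows: a group of 3 heavy atoms (2 carbon, 1 nitrogen; no ring) in place of a group of 4 heavy atoms (3 carbon, 1 nitrogen; no ring), on a saturated chain carbon, two bonds along the chain from a saturated ring carbon The new dimethylamino group carries no net charge, whereas the group it replaces carries a positive charge.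

Within the data shown here, no step between two measured compounds is available to lean on, so the size of this change can only be guessed. Compound 3 is expected to show a modest step toward a lower number, a 1.9-fold lower number from compound 1 to compound 3 (0.28 log units; within the scatter), which may well fall within the scatter. Compound 3 is therefore estimated at 1200 nM, within the range 400 nM to 4000 nM.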

Compound 3, half-maximal inhibitory concentration: 1000 nM
For compound 3 the middle estimate is 1.2-fold (0.08 log units) above the measured one; low and high end bracket the measured number.
By their numbers in this assay, from the lowest: compounds 3, 2 and 1 (each within the scatter of the next, the first and the last beyond it).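

Replacing the group of compound 1, which has a net charge of +1, with the dimethylamino group on the same saturated chain carbon gives a 2.3-fold lower number from compound 1 to compound 3 (0.36 log units; beyond the scatter) in this assay, a modest step but the first that can be read at this position. In this pair, the net charge is therefore not required for inhibition, and removing it does not weaken the compound. The change also removes one heavy atom and adds a hydrogen-bond acceptor, so this single step cannot show which difference matters, and no measurement at hand explains its direction.

The compounds shown leave open whether a primary amine or a methylamino group at this place would continue the step. They also leave open how a tert-butyl group or a longer chain carrying dimethylamino would compare.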